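Compound 1 to compound 4: adding a 4-methoxyphenyl

A few compounds are considered here, and "the series" means these few. Any claim that something is new, unique, unknown or untested is made for them only; others in the source may bear on it.

Values in a functional assay on RS4-11 cells (Homo sapiens) for inhibition, read by CCK-8 assay, with a stated time of 48 h, tested at 20 uM (on this read-out lower numbers stand for less inhibition of growth and higher numbers for more inhibition of growth at the one concentration tested), for the measured compounds
compound 1 `Cc1ccc(S(=O)(=O)Oc2ccccc2/C=C(\C#N)C(=O)Nc2nnc(C)s2)cc1` gives 33%
compound 2 `N#C/C(=C\c1ccccc1OS(=O)(=O)c1ccc([N+](=O)[O-])cc1)C(=O)Nc1nnc(-c2cccs2)s1` gives 40%
compound 3 `Cc1ccc(S(=O)(=O)Oc2cccc(/C=C(\C#N)C(=O)Nc3nnc(-c4ccccc4Cl)s3)c2)cc1` gives 44%

Compound 1 lies within the scatter of compound 2 and beyond the scatter below compound 3, so it stands at the low end of this small set without being clearly apart from all of it. The next compound to be measured is compound 4 `COc1ccc(Cc2nnc(NC(=O)/C(C#N)=C/c3ccccc3OS(=O)(=O)c3ccc(C)cc3)s2)cc1`, which differs from compound 1 by 4-methoxyphenyl in place of hydrogen on a saturated chain carbon bound to an aromatic carbon. Cut one bond further out, the same difference reads methyl to 4-methoxybenzyl.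

Going by the values given here, no two measured compounds differ in one place only, so this step has no direct precedent. Among the compounds with values here, the only guide is indirect: compound 2 at 40% and compound 3 at 44% also carry larger groups than methyl in that place, though both differ from compound 1 elsewhere as well. In this assay a modest upward step is therefore expected, estimated as a number 9 percentage points higher from compound 1 to compound 4 (within the scatter) and about the size of the scatter. Compound 4 is expected at 42% within an estimated range from 28% to 58% until the measurement is in.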

Compound 4, percent growth inhibition at one concentration: 70%
For compound 4 the middle estimate is 28 percentage points below the measured one; the measured number lies above the stated range.
By their numbers in this assay, from the lowest: compounds 1, 2 and 3 (each within the scatter of the next, the first and the last beyond it); then compound 4.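

In this assay, going by these compounds alone, going from methyl to 4-methoxybenzyl gives the first one-place comparison, and the result is a number 37 percentage points higher from compound 1 to compound 4 (beyond the scatter), with the rest of the structure held constant. Within the data shown here, this position on the shared core is therefore not merely tolerant of a 4-methoxyphenyl on the saturated chain carbon bound to an aromatic carbon: the growth-inhibition read-out responds strongly to this one change, which the earlier compounds could only hint at since each of them differs from compound 1 in more than one place. Nothing measured here offers an explanation for the size of this step.

This single step does not separate the contribution of the aromatic ring from that of its methoxy group, a question that a plain benzyl, a 4-hydroxybenzyl or an open butyl chain in the same place would address. Also open, from the compounds shown here alone, are whether an amine or a carboxylic acid on that ring would be accepted, and whether the gain carries over to other sulfonate groups and other attachment patterns on the core, or to full concentration-response measurements rather than one concentration.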